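This account rests on a few compounds, and the source may have more. Where it says the series, first, only, none or still open, it means among the compounds named here.

Compound 1 `C=C(C)C(=O)NC(=O)NC1=CS(=O)(=O)O[C@@]12[C@@H](CO[Si](C)(C)C(C)(C)C)O[C@@H](n1cc(C)c(=O)n(C)c1=O)[C@@H]2O[Si](C)(C)C(C)(C)C` and compound 2 `CCOC(=O)CNC(=O)NC1=CS(=O)(=O)O[C@@]12[C@@H](CO[Si](C)(C)C(C)(C)C)O[C@@H](n1cc(C)c(=O)n(C)c1=O)[C@@H]2O[Si](C)(C)C(C)(C)C` share one core and differ only in the group carried on an amide-type nitrogen. Within the data shown here, in a functional assay on MT4 cells (Homo sapiens) (a higher number here means that more compound is tolerated, a lower number that less compound is tolerated), compound 1 gives 1190 nM, the lowest of the two numbers known so far, and compound 2 gives 3780 nM; that is a 3.2-fold higher number from compound 1 to compound 2 (0.50 log units; beyond the scatter), so the ester-bearing chain is tolerated at a higher concentration than the unsaturated acyl group.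

Compound 3 `COC(=O)CCNC1=CS(=O)(=O)O[C@@]12[C@@H](CO[Si](C)(C)C(C)(C)C)O[C@@H](n1cc(C)c(=O)n(C)c1=O)[C@@H]2O[Si](C)(C)C(C)(C)C` is the next variant. It differs from compound 1 in this way: 2-(methoxycarbonyl)ethyl in place of ((1-methylethenyl)carbonyl)carbamoyl on an amine nitrogen. Here the whole acylcarbamoyl unit is gone and a short ester chain sits directly on the amine nitrogen, so the change is broader than the one between compound 1 and compound 2, but it points the same way, toward an ester in place of the unsaturated acyl group. On this basis the number for compound 3 in this assay is expected to rise, with a 2.5-fold higher number from compound 1 to compound 3 (0.40 log units; beyond the scatter) estimated as the step. The estimate for compound 3 is 3000 nM, within a range from 1200 nM to 8000 nM.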

Compound 3, half-maximal cytotoxic concentration: > 250000 nM
Compound 3: only a limit was reported; the forecaster's own chance of this, stated with the estimate: 5%; middle value at least 83-fold (1.92 log units) from the limit.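

In this assay compound 3 gives only a limit of the assay, not a number: the limit of > 250000 nM in this assay, at which 1 of the 3 values shown sits.

Replacing the whole carbamoyl-bearing group on the amine nitrogen with 2-(methoxycarbonyl)ethyl gives an at least 210-fold higher number from compound 1 to compound 3 (2.32 log units; beyond the scatter) and an at least 66-fold higher number from compound 2 to compound 3 (1.82 log units; beyond the scatter), far more than the change within the carbamoyl-bearing pair, a 3.2-fold higher number from compound 1 to compound 2 (0.50 log units; beyond the scatter). Compound 2 also carries an ester, so an ester alone does not go with the limit seen for compound 3, and what this position holds matters much more than the earlier pair suggested.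

As far as these compounds go, the true size of these steps stays unknown, since one end of each is a limit. Also open, from the compounds shown here alone, is whether a bare amine, a carboxylic acid in place of the ester, or a longer chain on this nitrogen would behave like compound 3 or like compound 1.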